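Chloro to fluoro on the 4-methoxyphenyl ring

This account rests on a few compounds, and the source may have more. Where it says the series, first, only, none or still open, it means among the compounds named here.

In an ADME assay on KB cells (Homo sapiens) for cytotoxicity, read by MTT assay, with a stated time of 72 h (a lower number here means a stronger inhibitor, a higher number a weaker inhibitor), compound 1 `C=CCOc1cc(C2=C(c3cc(OC)c(OC)c(OC)c3)C(=O)C(O)C2)ccc1OC` gives > 100 ug/mL, which is a limit of the assay and not a number. Among the compounds with values here, compound 2 `COc1ccc(C2=C(c3cc(OC)c(OC)c(OC)c3)C(=O)C(O)C2)cc1Cl` gives 2.5 ug/mL, the only true number so far, so it has no numerical comparator.

Compound 3 `COc1ccc(C2=C(c3cc(OC)c(OC)c(OC)c3)C(=O)C(O)C2)cc1F` has fluoro in place of chloro on an aromatic carbon, ortho to a methoxy group: fluoro in place of chloro on an aromatic carbon.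

Within the data shown here, only one measured step bears on this change, and only indirectly. The large step of an at least 40-fold lower number from compound 1 to compound 2 (1.60 log units; beyond the scatter) puts chloro in place of allyloxy at the same place, so the substituent here can matter in this assay. That step does not compare two halogens, and its size should not be carried over. No step beyond the scatter is therefore expected, and the estimated change is a 1.2-fold higher number from compound 2 to compound 3 (0.08 log units; within the scatter). For compound 3 the expected value in this assay is 3 ug/mL, with an estimated range of 0.8 ug/mL to 12 ug/mL.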

Compound 3, half-maximal inhibitory concentration: 4.5 ug/mL
For compound 3 the middle estimate is 1.5-fold (0.18 log units) below the measured one; low and high end bracket the measured number.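

In this assay the halogen exchange gives a 1.8-fold higher number from compound 2 to compound 3 (0.26 log units; within the scatter), so this position does not separate fluoro from chloro. Fluoro also stands clear of allyloxy, with an at least 22-fold lower number from compound 1 to compound 3 (1.34 log units; beyond the scatter), so the large gap seen with compound 2 is not specific to chloro and now holds for both halogens. The value of compound 1 is a limit and not a number, so both steps from it give only the least possible size: the limit of > 100 ug/mL in this assay, at which 1 of the 3 values shown sits.

The compounds shown place only allyloxy, chloro and fluoro at this position, so it remains open whether a hydroxy group, an amine or a methyl group would read like the halogens or like allyloxy. Also open, going by these compounds, is how a shorter ether such as ethoxy would read, which could show whether chain length alone separates compound 1 from the halogens.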